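Replacing an ethyl group on a pyrazole-bearing solubility series

A few compounds are considered here, and "the series" means these few. Any claim that something is new, unique, unknown or untested is made for them only; others in the source may bear on it.

Three compounds share a core in which a five-membered aromatic ring with two nitrogens carries a second ring. Compound 1 `Cc1cc(C)n(-c2nc3ccccc3c(=O)[nH]2)n1` gives 150000 nM in a physicochemical assay for solubility, at pH 7.4; a higher number here means a more soluble compound, a lower number a less soluble compound. Compound 2 `Cc1cc(C)n(-c2nc(-c3ccc(F)cc3)c(C#N)c(=O)[nH]2)n1` gives 30000 nM in this assay. Compound 3 `CCc1cc(C)nn1-c1nc(C(F)(F)F)cc(=O)[nH]1` gives 200000 nM in this assay, the highest of the three numbers, though compound 1 sits within the usual scatter of it while compound 2 lies beyond the scatter.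

Compound 4 `Cc1cc(Nc2ccccn2)n(-c2nc(C(F)(F)F)cc(=O)[nH]2)n1` has not yet been measured. It differs from compound 3 in one place: (pyridin-2-yl)amino in place of ethyl on an aromatic carbon. Going by the values given here, no measured pair in the set shows this change, so its size is unknown here. Among the compounds with values here, compound 2, the one measured compound that carries a six-membered aromatic ring on the core, gives 30000 nM, and on that basis a downward step beyond the scatter from compound 3 to compound 4 is expected, estimated at a 4.0-fold lower number from compound 3 to compound 4 (0.60 log units; beyond the scatter). Compound 4 is therefore expected to give about 50000 nM, within a range from 15000 nM to 150000 nM.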

Compound 4, solubility: 25000 nM
Beside the measured number, compound 4's estimate is 2.0-fold (0.30 log units) above it; low and high end bracket the measured number.
By their numbers in this assay, from the lowest: compounds 4 and 2 (each within the scatter of the next); then compounds 1 and 3 (each within the scatter of the next).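

In this assay, going by these compounds alone, (pyridin-2-yl)amino in place of ethyl on an aromatic carbon gives an 8.0-fold lower number from compound 3 to compound 4 (0.90 log units; beyond the scatter) and supplies the first measured one-place change. The earlier compounds shown here differed in more than one place, so they could not show that this position, on a five-membered aromatic ring with 2 nitrogen and next to the ring nitrogen, responds to a change of group beyond the scatter. No separate measurement accounts for the size of this step.

The compounds shown leave open whether the six-membered aromatic ring or the amino link is tied to the step, which a plain amine or a phenyl group at this place could help separate. They also leave open whether the same change gives a similar step on the core of compound 1.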